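The compounds below may be only part of what the source reports. "The series", "measured", "known", "first", "only" and "open" are said of these compounds alone.

Two chalcones sharing the same core were tested in a functional assay on cells (Tumor Cell line, Homo sapiens) for cytotoxicity; on this read-out lower numbers stand for stronger inhibition and higher numbers for weaker inhibition. Compound 1 `CN(C)Cc1cc(C(=O)/C=C/c2ccccc2)cc(CN(C)C)c1O` gave 21900 nM, and compound 2 `CN(C)Cc1cc(C(=O)/C=C/c2ccccc2Cl)cc(CN(C)C)c1O`, which carries chloro in place of hydrogen on an aromatic carbon, gave 9550 nM, a change of a 2.3-fold lower number from compound 1 to compound 2 (0.36 log units; beyond the scatter). Going by the values given here, compound 2 therefore stands at the lowest number of the two measured so far, with compound 1 as the only other point. Compound 3 `CN(C)Cc1cc(C(=O)/C=C/c2ccc([N+](=O)[O-])cc2)cc(CN(C)C)c1O` differs from compound 2 by 4-nitrophenyl in place of 2-chlorophenyl on a double-bonded chain carbon bound to a double-bonded chain carbon. Among the compounds with values here, the only step that bears on this change is the one from compound 1 to compound 2, which was modest and concerned a different substituent at a different place, so it offers no direct guide for a nitro group. Any step in this assay is therefore expected to be small, in either direction, and an estimated step of a 1.3-fold higher number from compound 2 to compound 3 (0.10 log units; within the scatter) is taken. Compound 3 is expected to give about 12000 nM, within a range from 4500 nM to 30000 nM.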

Compound 3, half-maximal inhibitory concentration: 8910 nM
For compound 3 the middle estimate is 1.3-fold (0.13 log units) above the measured one; the range from low to high includes it.
By their numbers in this assay, from the lowest: compounds 3 and 2 (each within the scatter of the next); then compound 1.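

In this assay the exchange of 2-chlorophenyl for 4-nitrophenyl on a double-bonded chain carbon bound to a double-bonded chain carbon gives a 1.1-fold lower number from compound 2 to compound 3 (0.03 log units; within the scatter) and so does not separate the two groups on this read-out. Adding a nitro group to the aromatic ring gives a 2.5-fold lower number from compound 1 to compound 3 (0.39 log units; beyond the scatter) as a modest step, so both substituted compounds now stand apart from compound 1, and none of the three goes against this. Nothing here offers an explanation for either step.

On these data alone, the exchange alters the group and its place on the ring together, so the contribution of each stays open. Whether 4-chlorophenyl, 2-nitrophenyl or an amine on this ring would fit the same picture also remains unsettled.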